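Replacing the fluorophenyl on compound 3 with cyclohexyl

The source may hold more compounds than are shown below. What is called first, only, known or untested is meant among the compounds shown, and "the series" means these compounds.

Measured so far:
compound 1, `CN1CCN(C(=S)SCc2ccc(C(=O)Nc3ccccc3N)cc2)CC1`, 36.6%
compound 2, `Nc1ccccc1NC(=O)c1ccc(CSC(=S)N2CCN(Cc3cccnc3)CC2)cc1`, 31.5%
compound 3, `Nc1ccccc1NC(=O)c1ccc(CSC(=S)N2CCN(c3ccccc3F)CC2)cc1`, 18.7%

All three were tested in a functional assay on A-375 cells (Homo sapiens) for antiproliferative activity, read by CCK-8 assay, with a stated time of 72 h, tested at 2 uM; on this read-out lower numbers stand for a weaker effect and higher numbers for a stronger effect at the one concentration tested. Compound 3 stands lowest of the three numbers: the step of a number 12.8 percentage points lower from compound 2 to compound 3 (beyond the scatter) and the step of a number 17.9 percentage points lower from compound 1 to compound 3 (beyond the scatter) both lie beyond the scatter, so on these numbers compound 3 is the weakest of the set.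

Compound 4, `Nc1ccccc1NC(=O)c1ccc(CSC(=S)N2CCN(C3CCCCC3)CC2)cc1`, differs from compound 3 in one place: cyclohexyl in place of 2-fluorophenyl on an amine nitrogen in a ring.

Both measured steps that lead to compound 3 brought in the 2-fluorophenyl group and lowered the read-out, one step being a number 17.9 percentage points lower from compound 1 to compound 3 (beyond the scatter) and the other a number 12.8 percentage points lower from compound 2 to compound 3 (beyond the scatter). Among the measured compounds shown here, no measured step brings in cyclohexyl, so nothing shows directly what that group does. Because a number 17.9 percentage points lower from compound 1 to compound 3 (beyond the scatter) and a number 12.8 percentage points lower from compound 2 to compound 3 (beyond the scatter) were modest losses on arrival of the 2-fluorophenyl, its departure is expected to recover part of that loss. The expected change is a number 7.3 percentage points higher from compound 3 to compound 4 (within the scatter). Compound 4 is therefore estimated at 26%, with a likely range from 12% to 40%.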

Compound 4, a percentage reported as inhibition, at one concentration (the size of the read-out at that concentration, not a potency): 31.7%
The estimate for compound 4 lay 5.7 percentage points below the measured number; the range from low to high includes it.
By their numbers in this assay, from the lowest: compound 3; then compounds 2, 4 and 1 (each within the scatter of the next).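

In this assay, putting the non-aromatic cyclohexyl in place of the aromatic 2-fluorophenyl on the ring amine nitrogen gives a number 13 percentage points higher from compound 3 to compound 4 (beyond the scatter) and shows that a six-membered carbon ring at this position need not bring the low number of compound 3. Cyclohexyl in place of methyl gives a number 4.9 percentage points lower from compound 1 to compound 4 (within the scatter) and cyclohexyl in place of (pyridin-3-yl)methyl gives a number 0.2 percentage points higher from compound 2 to compound 4 (within the scatter) in the same assay, so compound 1, compound 2 and compound 4 cannot be told apart despite their different groups, while compound 3 goes against this flat picture. Nothing available explains why cyclohexyl and 2-fluorophenyl differ here.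

Going by these compounds, what a plain phenyl would give, and so whether the fluorine or the aromatic ring goes with the lower number of compound 3, stays open. So does the effect of a carboxylic acid or a chain ending in a hydroxyl on this nitrogen.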